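Cyclohexyl for Ethyl on the Amino Nitrogen of Compound 1

This account rests on a few compounds, and the source may have more. Where it says the series, first, only, none or still open, it means among the compounds named here.

Of the compounds shown here, three sharing one core have been measured in a functional assay on the whole organism (strain BALB/c) for inhibition, with Mus musculus as the target, read by paw edema, with a stated time of 4 h, at a dose of 50 mg/kg by the oral route; on this read-out higher numbers stand for more inhibition at the one dose given (going by the name of the read-out) and lower numbers for less inhibition. Compound 1 `CCNc1nnc(-c2cc(-c3ccc(F)cc3F)ccc2O)s1` gives 50.2% and stands lowest of the three numbers. Compound 2 `Cn1c(-c2cc(-c3ccc(F)cc3F)ccc2O)n[nH]c1=S` gives 56.9%, a number that sits within the scatter of compound 1. Compound 3 `Oc1ccc(-c2ccc(F)cc2F)cc1-c1n[nH]c(=S)n1C1CCCCC1` gives 64.4%, which lies beyond the scatter above compound 1. Among the compounds with values here, the only step between measured compounds that differ in one place is a number 7.5 percentage points higher from compound 2 to compound 3 (within the scatter), where the group on an aromatic nitrogen is enlarged from methyl to cyclohexyl.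

The account now turns to compound 4 `Oc1ccc(-c2ccc(F)cc2F)cc1-c1nnc(NC2CCCCC2)s1`, which is not yet measured. It differs from compound 1 in one place: cyclohexyl in place of ethyl on a nitrogen on an aromatic ring. Within the data shown here, the step from compound 2 to compound 3 is the one measured change that bears on this, since there too a small alkyl group on an aromatic nitrogen gives way to cyclohexyl, and that step stayed within the scatter. On this basis the step from compound 1 to compound 4 is expected to be of a similar size and direction, a number 7.8 percentage points higher from compound 1 to compound 4 (within the scatter), a rise that may not clear the scatter. Compound 4 is therefore estimated to give 58% in this assay, with a range from 45% to 71%.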

Compound 4, a percentage reported as inhibition, in the whole organism at one dose (the size of the read-out at that dose, not a potency): 41.4%
Compound 4: middle estimate off by 16.6 percentage points, on the high side, outside the stated range (below it).
By their numbers in this assay, from the lowest: compounds 4, 1, 2 and 3 (each within the scatter of the next, the first and the last beyond it).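

In this assay, the change from ethylamino to cyclohexylamino on the core of compound 1 comes out as a number 8.8 percentage points lower from compound 1 to compound 4 (within the scatter), so at this nitrogen on an aromatic ring the six-membered carbon ring gives a number that cannot be told apart from that of ethyl. Set beside a number 7.5 percentage points higher from compound 2 to compound 3 (within the scatter), this shows that neither measured swap of a small alkyl group for cyclohexyl clears the scatter, and that one is printed as higher and the other as lower, so the earlier step gives no direction that holds at this position. Nothing on hand explains this outcome.

What the compounds shown leave open is whether any other group on this nitrogen, such as a longer butyl chain, a phenyl ring or a morpholine-bearing ethyl chain, would move the number beyond the scatter of compound 1. Also open, from the compounds shown here alone, is how a plain amine, with no carbon group on that nitrogen at all, would read at this one oral dose and time.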